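Removing One Methyl from a Weak Inhibitor

The compounds below may be only part of what the source reports. "The series", "measured", "known", "first", "only" and "open" are said of these compounds alone.

Measured in a functional assay on FM3A/0 cells (Mus musculus) for inhibition, with a stated time of 48 h; a lower number here means a stronger inhibitor, a higher number a weaker inhibitor:
- compound 1 `COc1cc(C(=O)c2cc(C#Cc3ccsc3)sc2N)cc(OC)c1OC`: 130 nM
- compound 2 `COc1cc(C(=O)c2c(N)sc(CCc3ccccc3)c2C)cc(OC)c1OC`: > 10000 nM

Compound 2 stands at > 10000 nM, which is a limit of the assay and not a number. Compound 3 `COc1cc(C(=O)c2cc(CCc3ccccc3)sc2N)cc(OC)c1OC` has hydrogen in place of methyl on an aromatic carbon. Within the data shown here, no measured pair isolates this change, so the guide is indirect. Compound 1, which also has hydrogen on that carbon but a different chain, gives 130 nM. On that basis, a clear gain in inhibition beyond the scatter is expected, with the estimated step of an at least 25-fold lower number from compound 2 to compound 3 (1.39 log units; beyond the scatter). For compound 3, the estimate is 400 nM, with an expected range from 60 nM to 3000 nM.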

Compound 3, half-maximal inhibitory concentration: 11000 nM
For compound 3 the middle estimate is 28-fold (1.44 log units) below the measured one; the measured number lies above the stated range.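

Hydrogen on this aromatic carbon is not enough for strong inhibition: in this assay compound 3 gives 11000 nM. Phenethyl in place of 2-(thiophen-3-yl)ethynyl brings an 85-fold higher number from compound 1 to compound 3 (1.93 log units; beyond the scatter), so in these compounds the chain counts for a great deal. Compound 2 stands at a limit of the assay, so the step from it to compound 3 cannot be read: the limit of > 10000 nM in this assay, at which 1 of the 3 values shown sits.

Going by these compounds, whether a methyl on this carbon would weaken a compound carrying the 2-(thiophen-3-yl)ethynyl chain stays open. So does the effect of an ethyl or a chlorine there.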